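Replacing an amide with an ethoxymethylidene amino group

A few compounds are considered here, and "the series" means these few. Any claim that something is new, unique, unknown or untested is made for them only; others in the source may bear on it.

Compound 1 `N#CC1=C(NC(=O)C2CC2)N(c2ccc(S(N)(=O)=O)cc2)C2=C(C(=O)CCC2)C1c1ccc(Cl)cc1Cl` is tested in a functional assay on Ehrlich cells (Mus musculus) for cytotoxicity, read by trypan blue exclusion, with a stated time of 2 h, tested at 50 ug/mL (a lower number here means a weaker effect, a higher number a stronger effect of the compound at the concentration tested), where compound 1 gives 40%. Its nearest neighbour, compound 2 `N#CC1=C(NC(=O)/C=C/c2ccccc2)N(c2ccc(S(N)(=O)=O)cc2)C2=C(C(=O)CCC2)C1c1ccc(Cl)cc1Cl`, gives 40% in this assay, and the step of no change at the digits printed from compound 1 to compound 2 (within the scatter) stays within the scatter. Compound 3 `CCO/C=N/C1=C(C#N)C(c2ccc(Cl)cc2Cl)C2=C(CCCC2=O)N1c1ccc(S(N)(=O)=O)cc1` is not yet measured. The change from compound 1 to compound 3 is a group of 5 heavy atoms (3 carbon, 1 nitrogen, 1 oxygen; no ring) in place of a group of 6 heavy atoms (4 carbon, 1 nitrogen, 1 oxygen; one three-membered non-aromatic ring of carbon only), on a double-bonded ring carbon. For the measured compounds named here, only the step from compound 1 to compound 2 touches the same position, and it showed no change, so no change beyond the scatter is expected, no change at the digits printed from compound 1 to compound 3 (within the scatter). Compound 3 is therefore estimated at 40%, between 25% and 55%.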

Compound 3, a percentage reported as activity, at one concentration (the size of the read-out at that concentration, not a potency): 35%
Compound 3: the middle estimate sits 5 percentage points above what was measured; low and high end bracket the measured number.
By their numbers in this assay, from the lowest: compounds 3, 1 and 2 (each within the scatter of the next).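

In this assay, the ethoxymethylidene amino group, which has 0 hydrogen-bond donors and no amide, gives a number 5 percentage points lower from compound 1 to compound 3 (within the scatter) and a number 5 percentage points lower from compound 2 to compound 3 (within the scatter). The earlier pair compared only two amides, whereas this result shows that the read-out at this position, on a double-bonded ring carbon, also holds up when the amide hydrogen is gone.

On these data alone, what a free amine, a carboxylic acid or a longer alkyl ether chain would give at this position remains open. Nothing measured here explains why the read-out holds across these groups.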